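A few compounds are considered here, and "the series" means these few. Any claim that something is new, unique, unknown or untested is made for them only; others in the source may bear on it.

Three compounds share one core and differ only in the groups attached to it. Compound 1 `Cc1ccc2oc(=O)c(C(=O)Nc3ccccc3C)cc2c1` gives 32000 nM in an assay on isolated protein for inhibition of coagulation factor XII (Homo sapiens); a lower number here means a stronger inhibitor, a higher number a weaker inhibitor. Compound 2 `Cc1cccc(NC(=O)c2cc3cc(C)ccc3oc2=O)c1` gives 10000 nM in this assay; the only measured step that joins two of these compounds in a single place is a 3.2-fold lower number from compound 1 to compound 2 (0.51 log units; beyond the scatter). Compound 3 `Cc1cccc(NC(=O)c2cc3cc(Cl)cc(Cl)c3oc2=O)c1` gives 25000 nM in this assay. Among the three numbers compound 3 stands second highest; its nearest neighbour is compound 1, whose number sits within the scatter of that of compound 3, while compound 2 lies beyond the scatter on the lower side.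

Compound 4 `Cc1cccc(NC(=O)c2cc3cc(Cl)cc(Br)c3oc2=O)c1` has not yet been measured. It differs from compound 3 by bromo in place of chloro on an aromatic carbon. Within the data shown here, none of the measured steps bears on this exchange: the single step on record, from compound 1 to compound 2, shifts the methyl group on the amide-type nitrogen and gives no guidance on a halogen of the core. With nothing to lean on, the change from compound 3 to compound 4 is expected to remain within the scatter, so the step of a 1.1-fold lower number from compound 3 to compound 4 (0.06 log units; within the scatter) is an estimate of essentially no movement. Compound 4 is therefore expected to give about 22000 nM in this assay, with a range from 8000 nM to 60000 nM.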

Compound 4, half-maximal inhibitory concentration: 10000 nM
Estimate against measurement, compound 4: 2.2-fold (0.34 log units) above, within the range that was stated.
By their numbers in this assay, from the lowest: compounds 2 and 4 (each within the scatter of the next); then compounds 3 and 1 (each within the scatter of the next).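

The exchange of chloro for bromo on this aromatic carbon, ortho to a fused ring and meta to a chloro group, gives a 2.5-fold lower number from compound 3 to compound 4 (0.40 log units; beyond the scatter) in this assay, a modest step but one beyond the scatter. Among these compounds, it is the first measured step to touch a halogen of the shared core rather than the methyl group on the phenyl ring of the amide, so it shows that this carbon of the core is not indifferent to which halogen it carries, even though the exchange swaps one heavy atom for one heavy atom and leaves the counts of hydrogen-bond donors and acceptors at zero. Nothing on record explains why the number falls with this exchange.

From the compounds shown here alone, what iodo, fluoro, a methoxy group or an amine would do on this same carbon remains open, so a single step cannot show whether the trend continues beyond bromo. Going by these compounds, it is equally open whether bromo in place of the remaining chloro group would give a step of similar size, or whether this step would hold with the methyl group elsewhere on the phenyl ring of the amide.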